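Chain lengthening in a lactone amide series

The compounds below may be only part of what the source reports. "The series", "measured", "known", "first", "only" and "open" are said of these compounds alone.

Compound 1 `O=C(CCCCCCCCc1ccccc1)N[C@H]1CCOC1=O` is a lactone amide with a phenyl-capped saturated chain. In a functional assay on PC-3 cells (Homo sapiens) for cytotoxicity, read by sulforhodamine B assay, with a stated time of 5 days (on this read-out higher numbers stand for weaker inhibition and lower numbers for stronger inhibition), compound 1 gives 67000 nM, the only full number shown for this set. Compound 2 `O=C(CCCCc1ccccc1)N[C@H]1CCOC1=O` is the shorter-chain analogue, and in this assay compound 2 gives only a limit, > 100000 nM. Compound 3 `O=C(CCCCCCCCCc1ccccc1)N[C@H]1CCOC1=O` extends the chain by one carbon: benzyl in place of phenyl on a saturated chain carbon, eight bonds along the chain from a carbonyl carbon. Among the measured compounds shown here, no measured step of this kind is available, so the expected step is small, within or near the scatter, with a slight lean toward stronger inhibition. Compound 3 is expected to give 50000 nM, between 20000 nM and 110000 nM, a step of a 1.3-fold lower number from compound 1 to compound 3 (0.13 log units; within the scatter).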

Compound 3, half-maximal inhibitory concentration: 75000 nM
For compound 3 the middle estimate is 1.5-fold (0.18 log units) below the measured one; the measured number falls inside the stated range.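

In this assay benzyl in place of phenyl on a saturated chain carbon, eight bonds along the chain from a carbonyl carbon, reads as a 1.1-fold higher number from compound 1 to compound 3 (0.05 log units; within the scatter) and so leaves the read-out unchanged. Among the compounds shown here, this is the first step in the set between two full numbers, and it shows no gain from this one-carbon extension. Both numbers stay close to the limit of the assay, where one compound of the set already sits: the limit of > 100000 nM in this assay, at which 1 of the 3 values shown sits.

As far as these compounds go, whether a still longer chain would stay as flat remains open. Also open, from the compounds shown here alone, is how an amine or a carboxylic acid in place of the phenyl would read.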